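The source may hold more compounds than are shown below. What is called first, only, known or untested is meant among the compounds shown, and "the series" means these compounds.

Measured in a physicochemical assay for solubility, read by spectrophotometry, measured as kinetic solubility, at pH 8, tested at 500 uM; on this read-out higher numbers stand for higher solubility and lower numbers for lower solubility:
- compound 1 `CNC(=O)c1ccncc1Nc1cc(-c2ccc3ccn(C)c3c2)c2nccnc2c1`: 4 ug/mL
- compound 2 `Cn1ccc2ccc(-c3cc(Nc4cnccc4C(=O)NCc4cncnc4)cc4nccnc34)cc21`: 233 ug/mL

Compound 2 holds the higher of these two numbers, well clear of compound 1. Compound 3 `Cn1cc(CNC(=O)c2ccncc2Nc2cc(-c3ccc4ccn(C)c4c3)c3nccnc3c2)cn1` differs from compound 2 in one group, 1-methyl-1H-pyrazol-4-yl in place of pyrimidin-5-yl on a saturated chain carbon bound to an amide-type nitrogen. The two groups match in those counts, though one ring is five-membered and the other six-membered.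

For the measured compounds named here, only one measured step bears on this place: a 58-fold higher number from compound 1 to compound 2 (1.77 log units; beyond the scatter), a large step beyond the scatter, made by putting pyrimidin-5-yl where hydrogen stood. Going by the values given here, it shows that this place can matter, but no measured step swaps one ring for another, so the guide is weak. A much smaller change is expected here, slightly downward and probably within the scatter. The expected change is a 1.6-fold lower number from compound 2 to compound 3 (0.19 log units; within the scatter). For compound 3 the estimated value is 150 ug/mL, with an expected range from 50 ug/mL to 245 ug/mL.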

Compound 3, solubility: 127 ug/mL
Compound 3: middle estimate off by 1.2-fold (0.07 log units), on the high side, within the range that was stated.
By their numbers in this assay, from the lowest: compound 1; then compounds 3 and 2 (each within the scatter of the next).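

In this assay, the swap of pyrimidin-5-yl for 1-methyl-1H-pyrazol-4-yl gives a 1.8-fold lower number from compound 2 to compound 3 (0.26 log units; within the scatter), so this assay does not separate the five-membered ring from the six-membered ring at this place. Putting 1-methyl-1H-pyrazol-4-yl where hydrogen stood gives a 32-fold higher number from compound 1 to compound 3 (1.50 log units; beyond the scatter), which shows that the large jump on the saturated chain carbon bound to an amide-type nitrogen is not confined to pyrimidin-5-yl. Nothing shown here gives a cause for either step.

As far as these compounds go, both groups that raise the number are aromatic rings with two ring nitrogens, so it remains open whether a plain phenyl ring would do the same. A morpholine ring or a dimethylamino group on the same carbon would test whether an aromatic ring is needed at all.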